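The compounds below may be only part of what the source reports. "The series", "measured", "known", "first", "only" and "open" are said of these compounds alone.

Measured compounds in a functional assay on the whole organism (strain NMRI) with Mus musculus as the target, with a stated time of 4 h; a higher number here means that more compound is needed for the effect, a lower number that less compound is needed:

Compound 1 `C#CCO/N=C/c1c(-c2ccc(F)cc2)nc2c(C)cccn12`: compound 1 gives 100 mg/kg
Compound 2 `C#CCO/N=C/c1c(-c2ccccc2)nc2c(C)cccn12`: compound 2 gives 100 mg/kg
Compound 3 `N#Cc1ccc(Cn2cc(CO/N=C/c3c(-c4ccccc4)nc4ccc(Br)cn34)nn2)cc1`: compound 3 gives 20 mg/kg

Compound 2 and compound 1 share a core and differ at one place only, the difference being (fluoro in place of hydrogen on an aromatic carbon). In this assay the step is no change at the digits printed from compound 2 to compound 1 (within the scatter), so the two values stand together within the scatter and neither can be ranked against the other.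

Compound 3 carries a different core. How its core differs from that of compound 2 is not broken down here. Its value is the lowest of the three, and the gaps to compound 1 and to compound 2 are both beyond the scatter, so compound 3 needs the least compound for the effect among the measured set.

Compound 4 `N#Cc1ccc(Cn2cc(CO/N=C/c3c(-c4ccc(F)cc4)nc4ccc(Br)cn34)nn2)cc1` is not yet measured. It relates to compound 3 as compound 1 relates to compound 2: the difference is fluoro in place of hydrogen on an aromatic carbon, and the place lines for the two changes read the same word for word, so this is the same change made on the other core.

For the measured compounds named here, the only measured example of this change, from compound 2 to compound 1, gave no change at the digits printed from compound 2 to compound 1 (within the scatter). On that basis the step expected from compound 3 to compound 4 in this assay is estimated as no change at the digits printed from compound 3 to compound 4 (within the scatter), resting on compound 3 and its value 20 mg/kg. Compound 4 is therefore expected to give about 20 mg/kg, with a plausible range from 10 mg/kg to 40 mg/kg.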

Compound 4, minimum effective dose: 100 mg/kg
Beside the measured number, compound 4's estimate is 5.0-fold (0.70 log units) below it, and the stated range ends below it.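

In this assay, the replacement of phenyl by 4-fluorophenyl does not carry over from one core to the other with the same result: the same change on two cores in this assay, no change at the digits printed (within the scatter) from compound 2 to compound 1 and a 5.0-fold higher number (0.70 log units; beyond the scatter) from compound 3 to compound 4, 5.0-fold (0.70 log units) apart, beyond the scatter of two such steps

On the core of compound 3, the step is a 5.0-fold higher number from compound 3 to compound 4 (0.70 log units; beyond the scatter), so there the fluoro in place of hydrogen goes with more compound being needed for the effect, whereas on the core of compound 2 it leaves the dose unresolved from that of the parent. This shows that, in this series, the outcome of the change depends on the core it is made on and that a step read on one core is a poor guide to the other, but it rests on a single pair per core and does not show which of the several differences between the two cores is responsible, nor why the step differs.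

Still open, going by these compounds, is whether the step on the core of compound 3 is specific to fluoro or would also appear with a chloro, a methoxy or an amine at the same place on the phenyl ring. Also open, on these data alone, is which part of that core has to be present for the step to appear, and whether a third core would follow compound 3 or compound 2.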